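From cyclopropylmethoxy to pyridinyloxy on a shared core

The source may hold more compounds than are shown below. What is called first, only, known or untested is meant among the compounds shown, and "the series" means these compounds.

Two compounds set the frame. Compound 1 `N#Cc1cc(N)cc(-n2nnc(-c3ccccn3)n2)c1` carries an amino group on its core and in a functional assay with metabotropic glutamate receptor 5 (Rattus norvegicus) as the target (on this read-out lower numbers stand for stronger inhibition and higher numbers for weaker inhibition), compound 1 gives 308 nM. Compound 2 `N#Cc1cc(OCC2CC2)cc(-n2nnc(-c3ccccn3)n2)c1` has cyclopropylmethoxy in its place, and in this assay compound 2 gives 975 nM, the highest of the two numbers; the step of a 3.2-fold higher number from compound 1 to compound 2 (0.50 log units; beyond the scatter) is the only one measured. Compound 3 `N#Cc1cc(Oc2cccnc2)cc(-n2nnc(-c3ccccn3)n2)c1` is the next step: pyridin-3-yl in place of cyclopropylmethyl on an oxygen on an aromatic ring. For the measured compounds named here, no measured step replaces the cyclopropylmethyl on that oxygen, so only the single step from compound 1 to compound 2 gives a sense of how much this place moves the number, and it moved it only modestly. Compound 3 is therefore expected to stay close to compound 2, with a step of a 1.1-fold lower number from compound 2 to compound 3 (0.03 log units; within the scatter) in this assay, most likely within the scatter. The estimate for compound 3 is 900 nM, with a range from 300 nM to 2700 nM.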

Compound 3, half-maximal inhibitory concentration: 15 nM
Beside the measured number, compound 3's estimate is 60-fold (1.78 log units) above it; measured number outside the range, below it.
By their numbers in this assay, from the lowest: compound 3; then compound 1; then compound 2.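

For the compounds shown here, the oxygen on the aromatic ring proves a far more sensitive place than the single earlier step suggested: in this assay, pyridin-3-yl in place of cyclopropylmethyl gives a 65-fold lower number from compound 2 to compound 3 (1.81 log units; beyond the scatter), whereas the only earlier step was the modest 3.2-fold higher number from compound 1 to compound 2 (0.50 log units; beyond the scatter). The (pyridin-3-yl)oxy group also outdoes the amino group, with a 21-fold lower number from compound 1 to compound 3 (1.31 log units; beyond the scatter), so compound 3 has the lowest number of the three, and its steps to both others lie beyond the scatter. Nothing available here accounts for this large drop.

The compounds shown leave open whether the gain needs the ring nitrogen of pyridin-3-yl, which a phenyl group on the same oxygen would test, and whether pyridin-2-yl or pyridin-4-yl would serve as well. They also leave open whether the oxygen itself matters, which a methylene or amine link in its place would address.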